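The compounds below may be only part of what the source reports. "The series", "measured", "known", "first", "only" and "open" are said of these compounds alone.

Measured compounds in a functional assay on MCF7 cells (Homo sapiens) for cytotoxicity, read by MTT assay, with a stated time of 72 h; on this read-out higher numbers stand for weaker inhibition and lower numbers for stronger inhibition:
Compound 1, `CNC(=O)c1cc(Oc2ccc(NC(=O)c3nn(-c4ccccc4OC(F)(F)F)c(=O)cc3C)cc2F)ccn1`, stands only at the limit > 40000 nM.
Compound 2, `Cc1cc(=O)n(-c2ccccc2C(F)(F)F)nc1C(=O)Nc1ccc(Oc2ncnc3sccc23)c(F)c1`, gives 13800 nM.
Compound 3, `Cc1cc(=O)n(-c2ccc(Br)cc2F)nc1C(=O)Nc1ccc(Oc2ncnc3sccc23)c(F)c1`, gives 13300 nM.

Compound 3 holds the lower of the two numbers, but the step of a 1.0-fold lower number from compound 2 to compound 3 (0.02 log units; within the scatter) is within the scatter, so compound 2 and compound 3 cannot be told apart on this read-out. Compound 1 sits at the limit described by the limit of > 40000 nM in this assay, at which 1 of the 3 values shown sits, and its value is a limit of the assay rather than a number.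

The compound still to be measured is compound 4, `Cc1cc(=O)n(-c2ccccc2OC(F)(F)F)nc1C(=O)Nc1ccc(Oc2ncnc3sccc23)c(F)c1`. It differs from compound 3 in one place: 2-(trifluoromethoxy)phenyl in place of 4-bromo-2-fluorophenyl on an aromatic nitrogen. Among the compounds with values here, the only measured step that bears on this change is the one from compound 2 to compound 3, in which a different aryl group on the same aromatic nitrogen left the number unchanged within the scatter. Compound 1 carries the 2-(trifluoromethoxy)phenyl group that enters here, but on a different core, and shows only a limit.

On this basis the expected step in this assay is small, with no direction beyond the scatter. Compound 4 is therefore estimated at 16000 nM, with a range from 6000 nM to 45000 nM. That estimate is expected to mean a step of a 1.2-fold higher number from compound 3 to compound 4 (0.08 log units; within the scatter).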

Compound 4, half-maximal inhibitory concentration: > 40000 nM
Compound 4: only a limit was reported; the forecaster's own chance of this, stated with the estimate: 25%; at least 2.5-fold (0.39 log units) between middle value and limit.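

In this assay, the aryl group on the aromatic nitrogen now proves able to move the read-out, which the earlier pair had not shown, since that change gave only a 1.0-fold lower number from compound 2 to compound 3 (0.02 log units; within the scatter). Placing 2-(trifluoromethoxy)phenyl there in place of 4-bromo-2-fluorophenyl gives an at least 3.0-fold higher number from compound 3 to compound 4 (0.47 log units; beyond the scatter), and trifluoromethoxy in place of trifluoromethyl on an aromatic carbon gives an at least 2.8-fold higher number from compound 2 to compound 4 (0.46 log units; beyond the scatter), so a change confined to a single group on that aryl ring is already enough to produce a step beyond the scatter. Compound 4 stands only at a limit, as does compound 1, so the step between these two cannot be read and the two steps just given fix only a lower bound on the change: the limit of > 40000 nM in this assay, at which 2 of the 4 values shown sit.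

The compounds shown do not tell whether this step belongs to the trifluoromethoxy group itself or would also appear with a methoxy group or a chlorine in its place. Nor can they say how far beyond the limit compound 4 lies, or whether an amine or a hydroxy group on the same aryl ring would read like compound 2 and compound 3 or like compound 4.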